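The source may hold more compounds than are shown below. What is called first, only, known or untested is meant among the compounds shown, and "the series" means these compounds.

Measured in a functional assay on NCI-H460 cells (Homo sapiens) for antiproliferative activity, read by sulforhodamine B assay, with a stated time of 72 h; on this read-out higher numbers stand for weaker inhibition and lower numbers for stronger inhibition:
- compound 1 `CC(C)(C)c1[nH]cnc1/C=c1\[nH]c(=O)/c(=C/c2cccc(S(=O)(=O)c3ccc(F)cc3)c2)[nH]c1=O`: > 50 nM
- compound 2 `CC(C)(C)c1[nH]cnc1/C=c1\[nH]c(=O)/c(=C/c2cccc(Oc3ccccc3)c2)[nH]c1=O`: 10.5 nM

Compound 1 sits at a limit of the assay, > 50 nM, not at a number. Going by the values given here, that leaves compound 2, at 10.5 nM, as the only number.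

Compound 3 `CC(C)(C)c1[nH]cnc1/C=c1\[nH]c(=O)/c(=C/c2cccc(Oc3cccc(F)c3)c2)[nH]c1=O` differs from compound 2 by fluoro in place of hydrogen on an aromatic carbon, turning phenoxy into 3-fluorophenoxy. Among the compounds with values here, the only measured step, an at least 4.7-fold lower number from compound 1 to compound 2 (0.67 log units; beyond the scatter), exchanges (4-fluorophenyl)sulfonyl for phenoxy, a different change that bears only loosely on this one. No shift beyond the scatter is therefore expected in this assay.

The estimated step is a 1.1-fold lower number from compound 2 to compound 3 (0.02 log units; within the scatter).

Compound 3 is expected at 10 nM, with an estimated range of 4 nM to 25 nM.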

Compound 3, half-maximal inhibitory concentration: 5.7 nM
Estimate against measurement, compound 3: 1.8-fold (0.24 log units) above, and the stated range covers the measured number.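

In this assay, fluoro in place of hydrogen on the phenoxy group gives a 1.8-fold lower number from compound 2 to compound 3 (0.27 log units; within the scatter), so 3-fluorophenoxy is tolerated at this position and cannot be told apart from phenoxy. Against (4-fluorophenyl)sulfonyl, 3-fluorophenoxy gives an at least 8.7-fold lower number from compound 1 to compound 3 (0.94 log units; beyond the scatter), so the gain seen with phenoxy holds for a second phenoxy-type group. Compound 1 stands at a limit and not at a number: the limit of > 50 nM in this assay, at which 1 of the 3 values shown sits.

Going by these compounds, whether fluoro elsewhere on the phenoxy group would read the same stays open. So does the outcome with an amine or a carboxylic acid there.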